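The compounds below may be only part of what the source reports. "The series", "measured", "known", "first", "only" and "open" are said of these compounds alone.

Working notes on the series

Of the compounds shown here, three with a shared core have been measured in a functional assay on MCF7 cells (Homo sapiens) for cytotoxicity, read by MTT assay, with a stated time of 48 h; a higher number here means a weaker inhibitor, a lower number a stronger inhibitor. Compound 1 `COc1ccccc1-c1nnc(SCCn2c([N+](=O)[O-])cnc2C)o1` gives 10800 nM. Compound 2 `CCOc1ccc(-c2nnc(SCCn3c([N+](=O)[O-])cnc3C)o2)cc1` gives 16600 nM in this assay, and compound 3 `COc1cc(OC)cc(-c2nnc(SCCn3c([N+](=O)[O-])cnc3C)o2)c1` gives 12800 nM. Taken as numbers alone, compound 1 sits at the low end of the three, but its gap to compound 3 and its gap to compound 2 each lie within the usual scatter of repeated measurements, so no order among the three can be read from these values.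

Compound 4 `Cc1ncc([N+](=O)[O-])n1CCSc1nnc(-c2ccccn2)o1` has not been measured. Relative to compound 1 the change is pyridin-2-yl in place of 2-methoxyphenyl on an aromatic carbon. For the measured compounds named here, no pair of measured compounds differs in one place, so there is no measured step to lean on for this change. The three measured values, all within the scatter of one another, give no sign that variation of the group at this position moves the number much, and a step of no more than the scatter, in either direction, is therefore expected from compound 1 to compound 4, a 1.1-fold higher number from compound 1 to compound 4 (0.05 log units; within the scatter). On that basis compound 4 is expected to give about 12000 nM in this assay, with a range of 5000 nM to 30000 nM.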

Compound 4, half-maximal inhibitory concentration: 39100 nM
Compound 4: middle estimate off by 3.3-fold (0.51 log units), on the low side, outside the stated range (above it).
By their numbers in this assay, from the lowest: compounds 1, 3 and 2 (each within the scatter of the next); then compound 4.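

Replacing 2-methoxyphenyl with pyridin-2-yl gives a 3.6-fold higher number from compound 1 to compound 4 (0.56 log units; beyond the scatter) in this assay, so the number at this position does respond to the group it carries, something the three earlier values, all within the scatter of one another, could not show. For the compounds shown here, this is the first step taken across a single change, and as one pair it describes this replacement, not the position as a whole. No measurement here bears on why the number rises with this change.

The compounds shown leave open whether the step follows from the ring nitrogen of pyridin-2-yl or from the loss of the methoxy group, a question that unsubstituted phenyl at this place would help to separate. Going by these compounds, how an aryl ring carrying an amine or a carboxylic acid would read in this assay also stays open.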